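Chloro for fluoro on the shared core

This account rests on a few compounds, and the source may have more. Where it says the series, first, only, none or still open, it means among the compounds named here.

Of the compounds shown here, two carry numbers so far in an ADME assay on the whole organism for pharmacokinetics, with Rattus norvegicus as the target, at a dose of 10 mg/kg by the oral route (a higher number here means more compound in the circulation at the dose given, a lower number less compound in the circulation), and the higher one is compound 1 `CC#C[C@@H](Cc1nnn[nH]1)c1ccc(OCc2ccc3sc(F)c(-c4ccccc4C)c3c2)cc1` at 3290 nM in this read-out. Compound 2 `CC#C[C@@H](Cc1nnn[nH]1)c1ccc(OCc2ccc3scc(-c4ccc(OCCCS(C)(=O)=O)cc4C)c3c2)cc1` stands at 694 nM on the same scale, a gap beyond the scatter. Within the data shown here, no measured pair differs in one place only, so no step can be read directly from the data.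

Compound 3 `CC#C[C@@H](Cc1nnn[nH]1)c1ccc(OCc2ccc3sc(Cl)c(-c4ccccc4C)c3c2)cc1` is the next to be measured. Set against compound 1, the change is chloro in place of fluoro on an aromatic carbon and it puts chloro in place of fluoro on an aromatic carbon of the five-membered aromatic ring with 1 sulfur, next to the ring sulfur and next to the ring atom that bears a 2-methylphenyl group.

Among the measured compounds shown here, with no halogen pair measured at this place, no step beyond the scatter is expected in this assay in either direction. The expected change a 1.1-fold lower number from compound 1 to compound 3 (0.04 log units; within the scatter) is therefore small, and the expectation rests on compound 1 at 3290 nM as its only anchor. For compound 3 the estimate is 3000 nM with an expected range from 1200 nM to 7000 nM at this dose.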

Compound 3, maximal plasma concentration: 8460 nM
Compound 3: middle estimate off by 2.8-fold (0.45 log units), on the low side; measured number outside the range, above it.
By their numbers in this assay, from the lowest: compound 2; then compound 1; then compound 3.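

Among these compounds, the first single-place step falls on the aromatic carbon next to the ring sulfur: in this assay, chloro in place of fluoro gives a 2.6-fold higher number from compound 1 to compound 3 (0.41 log units; beyond the scatter), a modest step but one beyond the scatter. Among the compounds shown here, this position is therefore not silent in this read-out, which the earlier compounds could not show, since no measured pair differed in one place only. For the compounds shown here, only one halogen atom changes, with no ring, hydrogen-bond donor, hydrogen-bond acceptor or net charge entering or leaving, and no measured property bears on the rise, so the step stands as an observation without an explanation.

The compounds shown leave open how other groups on this carbon would read in this assay, such as bromo, methyl, nitrile or methoxy, and so whether the step from fluoro to chloro belongs to halogens alone or extends beyond them. Also open, on these data alone, is whether the same exchange gives a step of similar size when the 2-methylphenyl group carries a longer chain ending in a methyl sulfone, as in compound 2.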